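The source may report more compounds than this note shows. Statements on the series, on what has been measured and on what is new or still open speak of the compounds shown alone.

Measured so far:

compound 1 `COc1cc(OC(F)(F)F)ccc1Nc1nc2nonc2nc1O` — 3800 nM
compound 2 `COc1cccc(Nc2nc3nonc3nc2O)c1` — 75400 nM
compound 3 `Oc1nc2nonc2nc1Nc1ccc2ccccc2c1` — 4000 nM

All three share the same core and differ only in the aromatic ring carried on the amine. In an assay on mitochondria from L6 cells (Rattus norvegicus) for activation, with a stated time of 90 min (a higher number here means that more compound is needed for the effect, a lower number that less compound is needed), compound 2 stands at the top of the three numbers: it needs far more compound than either compound 1 or compound 3, and both gaps lie beyond the usual scatter.

Compound 4 `Oc1nc2nonc2nc1Nc1cccc(F)c1` has not been measured yet. It differs from compound 2 in a single place: fluoro in place of methoxy on an aromatic carbon. Within the data shown here, no measured pair shows this particular exchange, so its effect cannot be read from the data; what the data do show is that the two other ring substitution patterns seen here go with much lower numbers than compound 2. A modest move toward a lower number is therefore expected, with a real chance that it stays within the scatter. The expected step is a 2.5-fold lower number from compound 2 to compound 4 (0.40 log units; beyond the scatter).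

Compound 4 is estimated to give about 30000 nM, with a range from 7000 nM to 120000 nM.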

Compound 4, half-maximal effective concentration: 31200 nM
The estimate for compound 4 lay 1.0-fold (0.02 log units) below the measured number; the measured number falls inside the stated range.
By their numbers in this assay, from the lowest: compounds 1 and 3 (each within the scatter of the next); then compound 4; then compound 2.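

Among these compounds, putting fluoro in place of methoxy on this aromatic carbon, meta to a large group, gives in this assay a 2.4-fold lower number from compound 2 to compound 4 (0.38 log units; beyond the scatter), the first step here between two compounds that differ in one place. The change removes one hydrogen-bond acceptor and one heavy atom, and this place on the ring thus accepts a different group with a modest, though real, shift in the number. Nothing measured here accounts for the size or direction of this shift.

Among the compounds shown here, the single pair cannot separate the loss of methoxy from the gain of fluoro, and it leaves open how other groups at this place, such as chloro, an amine or a carboxylic acid, would behave. Going by these compounds, whether the same exchange gives a similar step on compound 1, which also carries a methoxy group, also remains open.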